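Fluoro added to the anilide ring of the piperidin-2-yl oxalamide

The source may report more compounds than this note shows. Statements on the series, on what has been measured and on what is new or still open speak of the compounds shown alone.

Measured compounds:
compound 1 `Cc1nc(C(NC(=O)C(=O)Nc2ccc(Cl)cc2)C2CCNCC2)sc1CO` gives 81000 nM
compound 2 `Cc1nc(C(NC(=O)C(=O)Nc2ccc(Cl)cc2)C2CCCCN2)sc1CO` gives > 22000 nM
compound 3 `Cc1nc(C(NC(=O)C(=O)Nc2ccc(Cl)cc2)C2CCCNC2)sc1CO` gives 60200 nM

All three share one core and differ only in the piperidine attachment. In an ADME assay on TZM-b1 cells (Homo sapiens) for cytotoxicity, read by XTT assay, with a stated time of 3 days (a lower number here means that less compound is tolerated, a higher number that more compound is tolerated), compound 1 gives 81000 nM. Compound 3 in this assay gives 60200 nM, and the step of a 1.3-fold lower number from compound 1 to compound 3 (0.13 log units; within the scatter) is within the scatter. For compound 2 this assay reports only a limit, > 22000 nM, as noted in the limit of > 22000 nM in this assay, at which 1 of the 3 values shown sits; the steps a step that the limit leaves unreadable from compound 1 to compound 2 and a step that the limit leaves unreadable from compound 2 to compound 3 are therefore not readable in size.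

Compound 4 `Cc1nc(C(NC(=O)C(=O)Nc2ccc(Cl)c(F)c2)C2CCCCN2)sc1CO` differs from compound 2 by fluoro in place of hydrogen on an aromatic carbon. For the measured compounds named here, none of the measured steps touches the anilide ring; all three concern the piperidine, and the one readable among them was within the scatter. Going by the values given here, there is thus no measured step that bears directly on the change to compound 4, and the starting point is itself a limit. The expectation is a step that the limit leaves unreadable from compound 2 to compound 4, that is, no move beyond the scatter from what the series shows for compounds 1 and 3. Compound 4 is expected to give about 50000 nM in this assay, with a range from 20000 nM to 120000 nM, and a real chance that only a limit is again reported.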

Compound 4, half-maximal cytotoxic concentration: 58400 nM
Compound 4: middle estimate off by 1.2-fold (0.07 log units), on the low side; the range from low to high includes it.
By their numbers in this assay, from the lowest: compounds 4, 3 and 1 (each within the scatter of the next).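

In this assay, no step from compound 2 to compound 4 can be read, as compound 2 carries only a limit: the limit of > 22000 nM in this assay, at which 1 of the 4 values shown sits.

The compounds shown leave open whether fluoro in place of hydrogen on the anilide ring moves the number in this assay at all, and how piperidin-2-yl compares with piperidin-3-yl or piperidin-4-yl.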